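The source may report more compounds than this note shows. Statements on the series, on what has been measured and on what is new or still open speak of the compounds shown alone.

In a functional assay for inhibition, with Homo sapiens as the target (on this read-out higher numbers stand for weaker inhibition and lower numbers for stronger inhibition), compound 1 `O=C(NC[C@H](NS(=O)(=O)c1ccccc1)C(=O)O)c1cc2cc(OCCC3CCNCC3)ccc2[nH]1` gives 8 nM, the lowest of the three numbers shown. Compound 2 `O=C(NC[C@H](NS(=O)(=O)c1ccccc1)C(=O)O)c1cc2ccc(OCC3CCNCC3)cc2[nH]1` gives 15 nM, which lies within the scatter of compound 1, so the two cannot be ranked against each other. Going by the values given here, compound 3 `Cn1c(C(=O)NC[C@H](NS(=O)(=O)c2ccccc2)C(=O)O)cc2cc(OCCC3CCNCC3)ccc21` gives 21 nM; the only one-place step among the measured compounds is a 2.6-fold higher number from compound 1 to compound 3 (0.42 log units; beyond the scatter). Compound 4 `O=C(NC[C@H](NS(=O)(=O)c1ccccc1)C(=O)O)c1cc2cc(OCCn3ccnc3)ccc2[nH]1` has not yet been measured in this assay. It differs from compound 1 in one place: 1H-imidazol-1-yl in place of piperidin-4-yl on a saturated chain carbon, two bonds along the chain from an oxygen on an aromatic ring. Among the compounds with values here, no measured step touches that part of the molecule; the single step available concerns a methyl on the aromatic nitrogen of the shared core and says nothing about the saturated chain carbon where the new change sits. Within the data shown here, the expectation therefore rests on little: the one measured change to compound 1 weakened inhibition, and the present change swaps a larger part of the molecule, so a weaker number with a wide range is expected, a 5.0-fold higher number from compound 1 to compound 4 (0.70 log units; beyond the scatter). Compound 4 is estimated at 40 nM, between 10 nM and 200 nM.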

Compound 4, half-maximal inhibitory concentration: 45 nM
Compound 4: middle estimate off by 1.1-fold (0.05 log units), on the low side, within the range that was stated.
By their numbers in this assay, from the lowest: compounds 1, 2 and 3 (each within the scatter of the next, the first and the last beyond it); then compound 4.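

In this assay, going by these compounds alone, the step of a 5.6-fold higher number from compound 1 to compound 4 (0.75 log units; beyond the scatter) is the first measured change at the far end of the chain, with the ethoxy link left in place. It shows that the group at this end affects the result, and that 2-(1H-imidazol-1-yl)ethoxy can stand in for 2-(piperidin-4-yl)ethoxy with inhibition weakened but still present. Nothing measured here explains why the number rises.

This single swap changes the ring size, replaces a non-aromatic ring with an aromatic one and alters the nitrogen atoms, so those changes cannot be told apart. Going by these compounds, it remains open how pyridin-4-yl, an aromatic six-membered ring, or piperazin-1-yl, a non-aromatic ring with two nitrogens, would compare at the same saturated chain carbon.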